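From 5-bromothiophen-2-yl to thiophen-3-yl on a shared core

The compounds below may be only part of what the source reports. "The series", "measured", "known", "first", "only" and "open" are said of these compounds alone.

In an ADME assay on Vero cells (Chlorocebus sabaeus) for cytotoxicity, read by MTT assay, with a stated time of 96 h (a higher number here means that more compound is tolerated, a lower number that less compound is tolerated), compound 1 (`COc1cc(NCc2scnc2C)ccc1-c1cnco1`) gives 73700 nM and compound 2 (`COc1cc(NCc2cncs2)ccc1-c1cnco1`) gives 232000 nM while compound 3 (`COc1cc(NCc2ccc(Br)s2)ccc1-c1cnco1`) gives a similarly high micromolar reading (47300 nM). Where compound 3 stands follows from two steps: one within the scatter (a 1.6-fold lower number from compound 1 to compound 3 (0.19 log units; within the scatter)) and one beyond it (a 4.9-fold lower number from compound 2 to compound 3 (0.69 log units; beyond the scatter)). Compound 4 (`COc1cc(NCc2ccsc2)ccc1-c1cnco1`) carries thiophen-3-yl in place of 5-bromothiophen-2-yl on a saturated chain carbon bound to a nitrogen on an aromatic ring. For the measured compounds named here, no measured step makes this exact change. The nearest guide is the step in which hydrogen takes the place of methyl on an aromatic carbon (a 3.1-fold higher number from compound 1 to compound 2 (0.50 log units; beyond the scatter)), a modest rise. The modest step beyond the scatter that links compound 2 with compound 3 leaves the ring without a substituent on the higher side. A modest upward step is therefore expected in this assay and the estimate is (a 2.2-fold higher number from compound 3 to compound 4 (0.35 log units; beyond the scatter)). For compound 4 the estimated value is 105000 nM with an expected range from 45000 nM to 240000 nM in this measurement.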

Compound 4, half-maximal cytotoxic concentration: 181000 nM
Compound 4: the middle estimate sits 1.7-fold (0.24 log units) below what was measured, within the range that was stated.
By their numbers in this assay, from the lowest: compounds 3 and 1 (each within the scatter of the next); then compounds 4 and 2 (each within the scatter of the next).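

In this assay the swap on the saturated chain carbon gives a 3.8-fold higher number from compound 3 to compound 4 (0.58 log units; beyond the scatter) and shows that a thiophene ring can stand here with a high number once 5-bromothiophen-2-yl is gone, although bromine and the point of attachment change together and the step cannot be assigned to either alone. The step of a 1.3-fold lower number from compound 2 to compound 4 (0.11 log units; within the scatter) leaves thiophen-3-yl and 1,3-thiazol-5-yl unseparated in this assay while a 2.5-fold higher number from compound 1 to compound 4 (0.39 log units; beyond the scatter) places thiophen-3-yl clear of the 4-methyl-1,3-thiazol-5-yl group. No measurement is available that explains these steps.

Going by these compounds, it remains open whether thiophen-2-yl without bromine would read with compound 3 or with compound 4. A phenyl group or a longer chain at this place also remains untested in the compounds shown here.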